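Moving the Pyridine Nitrogen on a Pyrazole Chalcone

The source may hold more compounds than are shown below. What is called first, only, known or untested is meant among the compounds shown, and "the series" means these compounds.

Measured so far in a functional assay on Huh-7 cells (Homo sapiens) for inhibition, read by sulforhodamine B assay, with a stated time of 72 h; a higher number here means a weaker inhibitor, a lower number a stronger inhibitor:
compound 1, `COc1cc(C(=O)/C=C/c2cn(-c3ccccc3)nc2-c2ccsc2)cc(OC)c1OC`, gives 3600 nM
compound 2, `COc1cc(C(=O)/C=C/c2cn(-c3ccccc3)nc2-c2cccnc2)cc(OC)c1OC`, gives 1900 nM

Going by the values given here, of the two numbers, that of compound 2 is the lowest, but the only step between them, a 1.9-fold lower number from compound 1 to compound 2 (0.28 log units; within the scatter), lies within the scatter, so the two compounds cannot be told apart on this evidence.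

Compound 3 is `COc1cc(C(=O)/C=C/c2cn(-c3ccccc3)nc2-c2ccncc2)cc(OC)c1OC`. Its change from compound 2 is pyridin-4-yl in place of pyridin-3-yl on an aromatic carbon. Among the compounds with values here, the one measured step that bears on this place is a 1.9-fold lower number from compound 1 to compound 2 (0.28 log units; within the scatter), which exchanged a whole aryl group at the same carbon and still stayed within the scatter. Within the data shown here, no measured pair compares two pyridine isomers against each other, so there is no direct guide for the size of this smaller change. On that basis compound 3 is expected to sit close to compound 2, with a step of no change at the digits printed from compound 2 to compound 3 (within the scatter) that is not expected to exceed the scatter. Compound 3 is therefore estimated at 1900 nM in this assay, within a range of 800 nM to 4500 nM.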

Compound 3, half-maximal inhibitory concentration: 3500 nM
Compound 3: middle estimate off by 1.8-fold (0.27 log units), on the low side; the measured number falls inside the stated range.
By their numbers in this assay, from the lowest: compounds 2, 3 and 1 (each within the scatter of the next).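

In this assay, going by these compounds alone, the first direct comparison of two pyridine isomers at this carbon gives a 1.8-fold higher number from compound 2 to compound 3 (0.27 log units; within the scatter), so pyridin-4-yl and pyridin-3-yl, which have the same atoms and differ only in how they are joined, cannot be told apart here. Within the data shown here, the exchange of a whole aryl group gives the same reading for the new compound, with a 1.0-fold lower number from compound 1 to compound 3 (0.01 log units; within the scatter), so thiophen-3-yl and pyridin-4-yl cannot be separated either, and all three compounds now lie within the scatter of one another, with no step at this position yet rising beyond it. Nothing available accounts for these readings, and the numbers alone offer no explanation for them.

The three compounds leave open whether any group at this carbon, on the pyrazole next to the ring nitrogen, can produce a step beyond the scatter, since they cover only one thiophene and two pyridine isomers. A pyridin-2-yl group would complete the isomer series, while a phenyl ring carrying a carboxylic acid or a morpholine would test a far larger change at the same place.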